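A few compounds are considered here, and "the series" means these few. Any claim that something is new, unique, unknown or untested is made for them only; others in the source may bear on it.

Working notes on the series. In an ADME assay on microsomes from liver (Mus musculus) for metabolic stability, with a stated time of 10 min (a lower number here means that less of the compound is left, a higher number that more of the compound is left), compound 1 (`CC(=O)N1CC[C@H](C(=O)N2CC[C@](c3ccc(C(OCc4c(F)cccc4F)(C(F)(F)F)C(F)(F)F)cc3)(S(=O)(=O)c3ccc(F)cc3)C2)C1`) gives 57% and compound 2 (`CC(=O)N1CC[C@@H](C(=O)N2CC[C@](c3ccc(C(OCc4c(F)cccc4F)(C(F)(F)F)C(F)(F)F)cc3)(S(=O)(=O)c3ccc(F)cc3)C2)C1`) gives 55%. The change between these two is a number 2 percentage points lower from compound 1 to compound 2 (within the scatter), and the evidence on that pair is the fact that compounds 1 and 2 differ only in the configuration as drawn. Compound 3 (`O=C(N1CCOCC1)N1CC[C@](c2ccc(C(OCc3c(F)cccc3F)(C(F)(F)F)C(F)(F)F)cc2)(S(=O)(=O)c2ccc(F)cc2)C1`) stands lowest of the three at 18%. Two large steps lead to it: a number 39 percentage points lower from compound 1 to compound 3 (beyond the scatter) and a number 37 percentage points lower from compound 2 to compound 3 (beyond the scatter), each with morpholin-4-yl in place of 1-acetylpyrrolidin-3-yl on a carbonyl carbon.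

Compound 4 (`CC(=O)N1CCN(C(=O)N2CC[C@](c3ccc(C(OCc4c(F)cccc4F)(C(F)(F)F)C(F)(F)F)cc3)(S(=O)(=O)c3ccc(F)cc3)C2)CC1`) has 4-acetylpiperazin-1-yl in place of morpholin-4-yl on a carbonyl carbon. Only those two steps bear on this change, and they are an imperfect guide, since the group entering is not the one that left in them. A large rise in this assay is therefore expected, probably somewhat smaller than the drops seen. The estimated change is a number 25 percentage points higher from compound 3 to compound 4 (beyond the scatter). For compound 4 the expected value is 43%, with an estimated range of 23% to 64%.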

Compound 4, percent of the compound remaining: 59%
Compound 4: middle estimate off by 16 percentage points, on the low side; the range from low to high includes it.
By their numbers in this assay, from the lowest: compound 3; then compounds 2, 1 and 4 (each within the scatter of the next).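

In this assay, a number 41 percentage points higher from compound 3 to compound 4 (beyond the scatter), with 4-acetylpiperazin-1-yl in place of morpholin-4-yl, so the low number of compound 3 is not shared by every six-membered non-aromatic ring with 2 hetero atoms on this carbonyl carbon. Against the 1-acetylpyrrolidin-3-yl compounds, the readings are a number 4 percentage points higher from compound 2 to compound 4 (within the scatter) and a number 2 percentage points higher from compound 1 to compound 4 (within the scatter), so the acetylated piperazine ring and the acetylated pyrrolidine ring cannot be told apart here. Both comparisons point the same way, and they cover both drawn forms of the pyrrolidine group, for which the basis is: the fact that compounds 1 and 2 differ only in the configuration as drawn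

Still open, on these data alone, is how an unsubstituted piperazin-1-yl or a 4-methylpiperazin-1-yl group would read at this carbonyl carbon, which would test the acetyl group on its own. Also open, as far as these compounds go, is whether the morpholin-4-yl to 4-acetylpiperazin-1-yl step holds on a different core.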